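This account rests on a few compounds, and the source may have more. Where it says the series, first, only, none or still open, it means among the compounds named here.

Measured compounds:
compound 1, `C=CCn1c(=O)n(CCCCCCCC)c2nc(N)nc(O)c21` — 130%
compound 2, `CC1(C)O[C@@H]2[C@H](O1)[C@@H](CO)O[C@H]2n1c(=O)n(C/C=C/c2ccccc2)c2c(O)nc(N)nc21` — 16%

Compound 1 stands highest of the two numbers in a functional assay on the whole organism (B cells) with Mus musculus as the target (on this read-out higher numbers stand for larger maximal responses and lower numbers for smaller maximal responses), and compound 2 lies beyond the scatter below it. The two compounds differ in more than one place, so what separates them cannot be traced to any single group; their values only show that compound 1 gives the larger maximal response.

Compound 3, `C=CCn1c(=O)n(Cc2ccccc2)c2nc(N)nc(O)c21`, has not yet been tested in this assay. It differs from compound 1 in one place: phenyl in place of heptyl on a saturated chain carbon bound to an aromatic nitrogen. Among the measured compounds shown here, no measured pair shows this change on its own, so the size of the step rests on expectation alone. Compound 3 is expected to give a smaller maximal response than compound 1, with a step of a number 70 percentage points lower from compound 1 to compound 3 (beyond the scatter) in this assay. For compound 3 the estimate is 60%, with a range from 15% to 120%.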

Compound 3, largest response reached (reported as maximal response), in percent of the reference or control that the assay uses: 25%
Compound 3: middle estimate off by 35 percentage points, on the high side; the measured number falls inside the stated range.
By their numbers in this assay, from the lowest: compounds 2 and 3 (each within the scatter of the next); then compound 1.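

Phenyl in place of heptyl on a saturated chain carbon bound to an aromatic nitrogen gives, in this assay, a number 105 percentage points lower from compound 1 to compound 3 (beyond the scatter) and this is the first step in the series that can be read as a single change. It shows that this position is not indifferent: with the rest of the core of compound 1 held constant, the group carried by this chain carbon alone is enough to change the maximal response by a large margin. Nothing at hand accounts for the size of this step.

A single exchange cannot tell whether the aromatic ring or the shortened chain matters, and cyclohexyl, butyl or a longer chain at this place would help separate the two. On these data alone, how an amine or a carboxylic acid at the end of the heptyl chain would behave also stays open.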